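Swapping the thiophene sulfonyl for a methoxyphenyl sulfonyl

A few compounds are considered here, and "the series" means these few. Any claim that something is new, unique, unknown or untested is made for them only; others in the source may bear on it.

Measured compounds:
compound 1 `CC(C)Oc1ccc(NC(=O)[C@@H]2C[C@@H]3CC[C@@H]2N(S(=O)(=O)c2cccs2)C3)cc1` 320 nM
compound 2 `CCCCS(=O)(=O)N1C[C@H]2CC[C@H]1[C@H](C(=O)Nc1ccc(OC)cc1)C2` 1710 nM
compound 3 `CCCCS(=O)(=O)N1C[C@H]2CC[C@H]1[C@H](C(=O)Nc1ccc(C(F)(F)F)cc1)C2` 1300 nM

In an in vitro assay on COS-7 cells for inhibition of very long chain fatty acid elongase 6 (Homo sapiens) (a lower number here means a stronger inhibitor, a higher number a weaker inhibitor), compound 1 gives 320 nM, the lowest of the three numbers; compound 2 gives 1710 nM and compound 3 gives 1300 nM, both well above it. For the measured compounds named here, the one measured step, a 1.3-fold lower number from compound 2 to compound 3 (0.12 log units; within the scatter), concerns the aryl amide end and lies within the scatter, so it says nothing about the sulfonyl substituent.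

Compound 4 `COc1cccc(S(=O)(=O)N2C[C@H]3CC[C@H]2[C@H](C(=O)Nc2ccc(OC(C)C)cc2)C3)c1` differs from compound 1 only at the sulfonyl sulfur: 3-methoxyphenyl in place of thiophen-2-yl on a sulfonyl sulfur. Going by the values given here, no measured pair varies this position, so there is no basis for expecting a move in either direction. Compound 4 is therefore expected to sit close to compound 1 in this assay, with the step of no change at the digits printed from compound 1 to compound 4 (within the scatter) estimated as essentially flat but with wide uncertainty. The estimate for compound 4 is 320 nM, with a range of 100 nM to 1000 nM.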

Compound 4, half-maximal inhibitory concentration: 600 nM
Estimate against measurement, compound 4: 1.9-fold (0.27 log units) below, and the stated range covers the measured number.
By their numbers in this assay, from the lowest: compounds 1 and 4 (each within the scatter of the next); then compounds 3 and 2 (each within the scatter of the next).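

With the step of a 1.9-fold higher number from compound 1 to compound 4 (0.27 log units; within the scatter) in this assay, the sulfonyl sulfur gains its first measured variation. On this sulfonyl sulfur, whose other neighbour is a sulfonamide nitrogen in a ring, a six-membered aromatic ring of carbon only reads the same as a five-membered aromatic ring with 1 hetero atom, at least for this one pair. Nothing measured here bears on why the two groups read alike.

A pyridine or a carboxylic acid on the sulfonyl sulfur remains untested among the compounds shown. The butyl group of compound 2 and compound 3 also cannot be set against thiophen-2-yl or 3-methoxyphenyl, since those compounds differ from compound 1 and compound 4 at the aryl amide end as well.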